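A few compounds are considered here, and "the series" means these few. Any claim that something is new, unique, unknown or untested is made for them only; others in the source may bear on it.

Working notes on the series. In a functional assay (aorta) with Rattus norvegicus as the target (on this read-out lower numbers stand for stronger inhibition and higher numbers for weaker inhibition), compound 1 (`CC1(C)Oc2ccc(C#N)cc2[C@@H](/N=C(\NC#N)Oc2ccccc2)[C@@H]1O`) gives > 100000 nM, a limit of the assay and not a number. Compound 1 therefore stands at the limit of > 100000 nM in this assay, at which 1 of the 3 values shown sits. In this assay compound 2 (`CC1(C)Oc2ccc(C#N)cc2[C@@H](NC(=O)c2ccccc2)[C@@H]1O`) gives 30 nM and compound 3 (`CC1(C)Oc2ccc(C#N)cc2[C@@H](NC(=O)Nc2ccccn2)[C@@H]1O`) gives 440 nM.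

Compound 4 (`CC1(C)Oc2ccc(C#N)cc2[C@@H](/N=C(\NC#N)Nc2cccc([N+](=O)[O-])c2)[C@@H]1O`) carries (3-nitrophenyl)amino in place of phenoxy on a carbon with a double bond to nitrogen. For the measured compounds named here, no measured step changes this place. Going by the values given here, the only measured step, a 15-fold higher number from compound 2 to compound 3 (1.17 log units; beyond the scatter), has (pyridin-2-yl)amino in place of phenyl on a carbonyl carbon, so it bears on the change only indirectly. It is large and runs towards a higher number, yet compound 3 still reads 440 nM with an amino-linked ring on the shared core. On that basis, a large step towards a lower number is expected in this assay. The expected change is an at least 50-fold lower number from compound 1 to compound 4 (1.69 log units; beyond the scatter). The estimate for compound 4 is 2000 nM, with an expected range of 300 nM to 20000 nM.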

Compound 4, half-maximal inhibitory concentration: 670 nM
The estimate for compound 4 lay 3.0-fold (0.47 log units) above the measured number, and the stated range covers the measured number.
By their numbers in this assay, from the lowest: compound 2; then compounds 3 and 4 (each within the scatter of the next). At a limit, above all of these: compound 1.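

At the carbon with a double bond to nitrogen, replacing phenoxy with (3-nitrophenyl)amino gives, in this assay, an at least 140-fold lower number from compound 1 to compound 4 (2.17 log units; beyond the scatter). For the compounds shown here, this is the first direct reading at this place, and it shows that a value inside the measurable range is reachable here on the shared core, not only with the carbonyl-linked groups of compound 2 and compound 3. The size of the step is only a lower bound because compound 1 stands at a limit of the assay and not at a number: the limit of > 100000 nM in this assay, at which 1 of the 4 values shown sits.

From the compounds shown here alone, the amino link and the nitro group change together in this step, and which of them carries the change stays open. A plain phenylamino group at this place would divide the two.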